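The compounds below may be only part of what the source reports. "The series", "measured", "known", "first", "only" and "open" are said of these compounds alone.

The compounds were compared in an ADME assay on GES1 cells (Homo sapiens) for cytotoxicity, read by MTT assay, with a stated time of 24 h; on this read-out lower numbers stand for higher toxicity in this test and higher numbers for lower toxicity in this test. Compound 1 `O=c1[nH]cc(S(=O)(=O)Nc2ccccc2-c2cn(-c3ccccc3Cl)nn2)c(=O)[nH]1` gives 20800 nM in this assay. Compound 2 `O=c1[nH]cc(S(=O)(=O)Nc2ccccc2-c2cn(-c3cccc(Cl)c3)nn2)c(=O)[nH]1` gives no number but only a limit, > 100000 nM. The change from compound 1 to compound 2 is 3-chlorophenyl in place of 2-chlorophenyl on an aromatic nitrogen, and it produced an at least 4.8-fold higher number from compound 1 to compound 2 (0.68 log units; beyond the scatter); this step rests on (the limit of > 100000 nM in this assay, at which 1 of the 3 values shown sits). Compound 3 `O=c1[nH]cc(S(=O)(=O)Nc2cccc(-c3cn(-c4ccccc4Cl)nn3)c2)c(=O)[nH]1` gives 14000 nM in this assay. The values of compound 3 and compound 1 lie within the scatter of each other, and the difference between the core of compound 1 and the core of compound 3 is not broken down here. Compound 4 `O=c1[nH]cc(S(=O)(=O)Nc2cccc(-c3cn(-c4cccc(Cl)c4)nn3)c2)c(=O)[nH]1` is still to be measured. Among the compounds with values here, compound 4 differs from compound 3 by 3-chlorophenyl in place of 2-chlorophenyl on an aromatic nitrogen, the same change, at the same place, as the one from compound 1 to compound 2. The expected step is a 5.7-fold higher number from compound 3 to compound 4 (0.76 log units; beyond the scatter), because the earlier step gave an at least 4.8-fold higher number from compound 1 to compound 2 (0.68 log units; beyond the scatter). Compound 4 is therefore estimated at 80000 nM in this assay, expected to fall between 35000 nM and 200000 nM, with a fair chance that only a limit is reported.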

Compound 4, half-maximal cytotoxic concentration: 26200 nM
The estimate for compound 4 lay 3.1-fold (0.48 log units) above the measured number; measured number below the stated range.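

On the core of compound 3, 3-chlorophenyl in place of 2-chlorophenyl gave a 1.9-fold higher number from compound 3 to compound 4 (0.27 log units; within the scatter) in this assay, so the step that lay beyond the scatter on the core of compound 1 was not repeated beyond the scatter on this second core. Set side by side, the two steps can be said neither to agree nor to disagree: the same change on two cores in this assay, an at least 4.8-fold higher number (0.68 log units; beyond the scatter) from compound 1 to compound 2 and a 1.9-fold higher number (0.27 log units; within the scatter) from compound 3 to compound 4; the limit leaves it open whether they differ

From the compounds shown here alone, compound 2 gives only a limit, > 100000 nM, and the size of the step on the core of compound 1 therefore stays unknown; the two pairs show that the change does not reliably carry a step beyond the scatter from one core to the other, but not how far its size depends on the core.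

The compounds shown leave open how a fluorine atom or a methoxy group in place of the chlorine would read in this assay on either core. They also leave open whether an amine or a carboxylic acid on that phenyl ring would behave alike on the two cores.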